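Trimming the biphenyl of compound 2 to a phenyl

The source may report more compounds than this note shows. Statements on the series, on what has been measured and on what is new or still open speak of the compounds shown alone.

The study set out two measured compounds. Compound 1, `C=C(Br)C(=O)Nc1ccc2[nH]c(C(=O)O)cc2c1`, is the stronger of the pair: in a functional assay on K562 cells (Homo sapiens) for antiproliferative activity (a higher number here means a weaker inhibitor, a lower number a stronger inhibitor), compound 1 gives 5600 nM. Compound 2, `C=C1CC(COc2cc(C(=O)O)n(C)n2)(c2ccc(-c3ccccc3)cc2)OC1=O`, shares nothing of that core. In this assay compound 2 returns only a limit of the assay, > 10000 nM, and no number. Compound 2 therefore sits at the top of the numbers shown, on the line where (the limit of > 10000 nM in this assay, at which 1 of the 2 values shown sits).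

Compound 3, `C=C1CC(COc2cc(C(=O)O)n(C)n2)(c2ccccc2)OC1=O`, is the untested relative of compound 2. The change is hydrogen in place of phenyl on an aromatic carbon. Among the compounds with values here, no pair of measured compounds in this set differs in a single place, so no measured step shows what such a change does; the size of the step in this assay is unknown, and the working expectation is no movement beyond the usual scatter, in either direction. The step from compound 2 to compound 3 is thus expected to be a step that the limit leaves unreadable from compound 2 to compound 3. Compound 3 is estimated to give 15000 nM in this assay, with a range from 5000 nM to 50000 nM, and most likely another limit rather than a number.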

Compound 3, half-maximal inhibitory concentration: > 10000 nM
Compound 3 ended at the assay's limit; the forecaster's own chance of this, stated with the estimate: 70%; the middle value lies beyond the limit too.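

Compound 2 and compound 3 each return only a limit of the assay and no number, so the step between them cannot be read: the limit of > 10000 nM in this assay, at which 2 of the 3 values shown sit.

The compounds shown leave open whether hydrogen in place of phenyl on an aromatic carbon moves the activity in this assay at all, in either direction.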